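Chain extension on the triazole arm of a bromoquinoline series

A few compounds are considered here, and "the series" means these few. Any claim that something is new, unique, unknown or untested is made for them only; others in the source may bear on it.

Compound 2, `COc1nc2ccc(Br)cc2cc1C(c1ccccc1)n1cc(CCO)nn1`, gives 8.46% in an ADME assay on SK-OV-3 cells (Homo sapiens) for cytotoxicity, read by sulforhodamine B assay, with a stated time of 48 h, tested at 10 uM (a lower number here means less inhibition, a higher number more inhibition at the concentration tested (going by the name of the read-out)), the higher of the two numbers recorded so far. Its nearest neighbour is compound 1, `CCCCCCCCc1cn(C(c2ccccc2)c2cc3cc(Br)ccc3nc2OC)nn1`, which in this assay gives 2.06%. Within the data shown here, the only step measured at this position, a number 6.4 percentage points higher from compound 1 to compound 2 (within the scatter), was within the scatter, so the chain on that carbon has so far made no difference that can be trusted.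

Compound 3, `COc1nc2ccc(Br)cc2cc1C(c1ccccc1)n1cc(CCCCCO)nn1`, is not yet measured. The change from compound 2 is 3-hydroxypropyl in place of hydroxy on a saturated chain carbon, two bonds along the chain from an aromatic carbon. Among the measured compounds shown here, the one step that bears on it, a number 6.4 percentage points higher from compound 1 to compound 2 (within the scatter), was within the scatter, so the expectation for compound 3 is a step of a number 2.5 percentage points lower from compound 2 to compound 3 (within the scatter), that is, none beyond the scatter. Compound 3 is therefore estimated to give 6% in this assay, within a range from 0% to 20%.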

Compound 3, a percentage reported as inhibition, at one concentration (the size of the read-out at that concentration, not a potency): 8.69%
Beside the measured number, compound 3's estimate is 2.7 percentage points below it, and the stated range covers the measured number.
By their numbers in this assay, from the lowest: compounds 1, 2 and 3 (each within the scatter of the next).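

Taking the 2-hydroxyethyl arm out to 5-hydroxypentyl in this assay gives a number 0.2 percentage points higher from compound 2 to compound 3 (within the scatter) and so shows no trustworthy effect of this difference in chain length. Hydroxy in place of propyl, five bonds along the chain from an aromatic carbon, gives a number 6.6 percentage points higher from compound 1 to compound 3 (within the scatter) and so also shows no difference that can be trusted, now for a second chain that carries hydroxy. No measurement offers any explanation for these results.

The compounds shown leave open whether any group on this arm can produce a step beyond the scatter. An amine or a carboxylic acid in place of the hydroxy, or a phenyl ring in place of the chain, would put that question to the shared core.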